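The compounds below may be only part of what the source reports. "The series", "measured", "known", "first", "only" and "open" are said of these compounds alone.

Compound 1 `Cc1cccc(C(=O)Nc2ncc(-c3ccccc3)n2C)c1` is known in a toxicity assay on THP-1 cells (Homo sapiens) for inhibition (a lower number here means that less compound is tolerated, a higher number that more compound is tolerated), only as a limit, > 50000 nM, which is the limit of > 50000 nM in this assay, at which 1 of the 3 values shown sits. Compound 2 `COc1ccc(-c2cnc(NC(=O)c3cccc(C)c3)n2C)cc1` also reaches only a limit in this assay, > 100000 nM. Compound 3 `COc1ccc(-c2cnc(NC(=O)c3ccc([N+](=O)[O-])cc3)n2C)cc1` likewise gives a limit in this assay, > 100000 nM. Going by the values given here, the one measured step, a step that the two limits leave unreadable from compound 1 to compound 2, has no readable size; both of its ends are limits, as the limit of > 100000 nM in this assay, at which 2 of the 3 values shown sit, shows. Compound 4 `Cn1c(-c2ccccc2)cnc1NC(=O)C1CCCCC1` differs from compound 1 by cyclohexyl in place of 3-methylphenyl on a carbonyl carbon. Among the compounds with values here, no measured step concerns a change of this kind, and the single step that exists cannot be read, so no step beyond the scatter can be expected in this assay in either direction. With all three known values sitting at a limit, compound 4 is expected to sit at a limit as well, estimated at 80000 nM with a range from 30000 nM to 200000 nM. The step that the limit leaves unreadable from compound 1 to compound 4 that this estimate means is expected to lie within the scatter.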

Compound 4, half-maximal cytotoxic concentration: > 100000 nM
Compound 4 gave a limit, no number; the forecaster's own chance of this, stated with the estimate: 75%; at least 1.2-fold (0.09 log units) between middle value and limit.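

Compound 4, like compound 1, is known only as a limit in this assay, so the step between these two compounds cannot be read. The compounds shown leave open what concentration any of them tolerates in this assay, and whether exchanging 3-methylphenyl for cyclohexyl changes it.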